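A Fluorine Added to the Phenyl Ring of Compound 3

This account rests on a few compounds, and the source may have more. Where it says the series, first, only, none or still open, it means among the compounds named here.

Measured compounds:
compound 1, `Cn1nnnc1SCC(=O)N/N=c1/scc(-c2ccccc2)n1-c1ccccc1`: 67.7 ug/mL
compound 2, `O=C(CSc1ncccn1)N/N=c1/scc(-c2ccc(Br)cc2)n1-c1ccccc1`: a limit, > 200 ug/mL
compound 3, `O=C(CSc1nnnn1-c1ccccc1)N/N=c1/scc(-c2ccccc2)n1-c1ccccc1`: 8.3 ug/mL

For the measured compounds named here, in a functional assay on C6 cells (Rattus norvegicus) for cytotoxicity, read by MTT assay, with a stated time of 24 h (on this read-out lower numbers stand for stronger inhibition and higher numbers for weaker inhibition), compound 3 gives the lowest of the two numbers obtained; the nearest is compound 1, and the only measured step, an 8.2-fold lower number from compound 1 to compound 3 (0.91 log units; beyond the scatter), came with phenyl in place of methyl on an aromatic nitrogen. For compound 2 the assay reports only a limit, (the limit of > 200 ug/mL in this assay, at which 1 of the 3 values shown sits), not a number.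

Compound 4, `O=C(CSc1nnnn1-c1ccccc1)N/N=c1/scc(-c2ccc(F)cc2)n1-c1ccccc1`, differs from compound 3 by fluoro in place of hydrogen on an aromatic carbon. Going by the values given here, no measured step touches this ring, so no change beyond the usual scatter is expected, and the step of a 1.1-fold higher number from compound 3 to compound 4 (0.04 log units; within the scatter) is an estimate rather than a measured result. In this assay compound 4 is expected to give about 9 ug/mL, within the range 3.5 ug/mL to 25 ug/mL.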

Compound 4, half-maximal inhibitory concentration: 24.3 ug/mL
Compound 4: middle estimate off by 2.7-fold (0.43 log units), on the low side; measured number inside the range.
By their numbers in this assay, from the lowest: compound 3; then compound 4; then compound 1. At a limit, above all of these: compound 2.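

For the compounds shown here, this is the first measured step at the phenyl ring on the shared core, and that ring turns out not to be a silent position. In this assay, fluoro in place of hydrogen, para to a large group, gives a 2.9-fold higher number from compound 3 to compound 4 (0.47 log units; beyond the scatter), so a change of one heavy atom here weakens inhibition. Nothing measured here accounts for this loss.

Going by these compounds, whether chloro, methoxy or an amine at this carbon would also weaken inhibition stays open. So does whether fluoro costs as much when methyl replaces the phenyl on the aromatic nitrogen.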